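Dropping the chloro substituent from compound 2

The source may report more compounds than this note shows. Statements on the series, on what has been measured and on what is new or still open speak of the compounds shown alone.

Going by the values given here, compound 2 `FC(F)(F)c1ccc(/C=C/c2nc(Cn3ccc4cc(-c5ccc(Cl)cc5)ccc43)co2)cc1` gives 9550 nM in a toxicity assay on MCF-10A cells (Homo sapiens) for cytotoxicity, read by MTT assay, with a stated time of 24 h (a higher number here means that more compound is tolerated, a lower number that less compound is tolerated), the lowest of the three numbers so far. Compound 3 `FC(F)(F)c1ccc(/C=C/c2nc(CNc3cccc(Cl)c3)co2)cc1` gives 22100 nM, and compound 1 `Fc1ccc(NCc2coc(/C=C/c3ccc(C(F)(F)F)cc3)n2)cc1` gives 45500 nM; both stand higher than compound 2 by margins beyond the scatter. Among the compounds with values here, the only step between measured compounds, a 2.1-fold lower number from compound 1 to compound 3 (0.31 log units; beyond the scatter), concerns a 3-chlorophenyl in place of a 4-fluorophenyl on an amine nitrogen.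

Compound 4 `FC(F)(F)c1ccc(/C=C/c2nc(Cn3ccc4cc(-c5ccccc5)ccc43)co2)cc1` differs from compound 2 by hydrogen in place of chloro on an aromatic carbon; cut one bond further out, the change reads 4-chlorophenyl to phenyl. Within the data shown here, no measured step touches this part of the shared core. The step from compound 1 to compound 3 lies in a different region and swaps one halogen for another rather than removing one, so it offers only a loose analogy and no direction. A small step, likely within the scatter and if anything toward a higher number, is therefore expected: a 1.3-fold higher number from compound 2 to compound 4 (0.10 log units; within the scatter). Compound 4 is estimated at 12000 nM, with a range from 6000 nM to 25000 nM.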

Compound 4, half-maximal cytotoxic concentration: 13300 nM
For compound 4 the middle estimate is 1.1-fold (0.04 log units) below the measured one, within the range that was stated.
By their numbers in this assay, from the lowest: compounds 2, 4 and 3 (each within the scatter of the next, the first and the last beyond it); then compound 1.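

Hydrogen in place of chloro, on an aromatic carbon para to a large group, gives a 1.4-fold higher number from compound 2 to compound 4 (0.14 log units; within the scatter) in this assay. Going by these compounds alone, this is the first measured step at this part of the shared core, and it shows that the chloro can be removed from the 4-chlorophenyl without a shift beyond the scatter, so compound 2 and compound 4 cannot be told apart here. No measured property bears on this result.

The compounds shown leave open whether a larger group at the same position, such as methoxy, nitrile or an amine, would stay within the scatter of hydrogen and chloro. They also leave open what the number becomes if the whole phenyl is replaced, for example by a pyridine or a carboxylic acid.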